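Benzyl for pentyl on the methoxy-bearing core

The compounds below may be only part of what the source reports. "The series", "measured", "known", "first", "only" and "open" are said of these compounds alone.

Four compounds share one core and differ in two places: the chain on the ether oxygen and a substituent on the fused aromatic ring. Compound 2 `CCCCCOCNc1n[n+]([O-])c2ccccc2[n+]1[O-]` and compound 1 `[O-][n+]1nc(NCOCc2ccccc2)[n+]([O-])c2ccccc21` carry the unsubstituted core; in a functional assay on PC-3 cells (Homo sapiens) for cytotoxicity, read by MTT assay, with a stated time of 72 h (on this read-out lower numbers stand for stronger inhibition and higher numbers for weaker inhibition), compound 2 gives 8510 nM and compound 1 gives 11900 nM. The change between them is phenyl in place of butyl on a saturated chain carbon bound to an oxygen on a saturated carbon and the step is a 1.4-fold higher number from compound 2 to compound 1 (0.15 log units; within the scatter), so the two numbers cannot be told apart.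

Compound 3 `CCCCCOCNc1n[n+]([O-])c2cc(OC)ccc2[n+]1[O-]` differs from compound 2 by methoxy in place of hydrogen on an aromatic carbon; in this assay compound 3 gives 30900 nM, a step of a 3.6-fold higher number from compound 2 to compound 3 (0.56 log units; beyond the scatter). Compound 3 therefore stands at the high end of the three measured numbers, beyond the scatter from both compound 1 and compound 2.

Compound 4 `COc1ccc2c(c1)[n+]([O-])nc(NCOCc1ccccc1)[n+]2[O-]` is not yet measured. It differs from compound 3 by phenyl in place of butyl on a saturated chain carbon bound to an oxygen on a saturated carbon, which is the same change as that from compound 2 to compound 1, made on the same place and at the same attachment, only on the core that carries the methoxy group. For the measured compounds named here, the one earlier instance of this change, a 1.4-fold higher number from compound 2 to compound 1 (0.15 log units; within the scatter), stayed within the scatter, so from compound 3 to compound 4 a step of about a 1.4-fold higher number from compound 3 to compound 4 (0.14 log units; within the scatter) is expected, resting on that single pair. Going by the values given here, with only one precedent and the core difference methoxy in place of hydrogen on an aromatic carbon untested in combination with the benzyl chain, the range is kept wide. Compound 4 is estimated at 43000 nM in this assay, between 18000 nM and 100000 nM.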

Compound 4, half-maximal inhibitory concentration: 88500 nM
For compound 4 the middle estimate is 2.1-fold (0.31 log units) below the measured one; the measured number falls inside the stated range.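

In this assay the change from pentyl to benzyl gives a 2.9-fold higher number from compound 3 to compound 4 (0.46 log units; beyond the scatter) on the methoxy-bearing core, and this step cannot be told apart from its counterpart on the unsubstituted core: the same change on two cores in this assay, a 1.4-fold higher number (0.15 log units; within the scatter) from compound 2 to compound 1 and a 2.9-fold higher number (0.46 log units; beyond the scatter) from compound 3 to compound 4, 2.0-fold (0.31 log units) apart, within the scatter of two such steps

The methoxy change on the benzyl-bearing compounds gives a 7.4-fold higher number from compound 1 to compound 4 (0.87 log units; beyond the scatter), which likewise agrees with the same change on the pentyl-bearing compounds: the same change on two cores in this assay, a 3.6-fold higher number (0.56 log units; beyond the scatter) from compound 2 to compound 3 and a 7.4-fold higher number (0.87 log units; beyond the scatter) from compound 1 to compound 4, 2.0-fold (0.31 log units) apart, within the scatter of two such steps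

Both changes therefore carry across this pair of cores within the scatter, but the two comparisons draw on the same four numbers and amount to one check rather than two, and they do not show that the steps are equal in size, since the chain step lies within the scatter on one core and beyond it on the other, or that either change would carry to any further core.

Still open, on these data alone, is whether the chain change keeps its size with another group on the fused aromatic ring, such as a chlorine or an amine, in place of methoxy. Also open, as far as these compounds go, is how a longer chain or a benzyl bearing a carboxylic acid on its ring would read against the pentyl and benzyl compounds.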